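Swapping a Guanidine Chain End for Dimethylamino

The compounds below may be only part of what the source reports. "The series", "measured", "known", "first", "only" and "open" are said of these compounds alone.

Of the compounds shown here, two have been measured in an assay on SH-SY5Y cells for inhibition of Voltage-dependent N-type calcium channel subunit alpha-1B (Homo sapiens), read by FLIPR and calcium flux, with stated times of 600 s and 300 s, in the presence of a further agent that is not named here; a lower number here means a stronger inhibitor, a higher number a weaker inhibitor. Compound 1 `CN(C)CCCOc1ccc(CNc2nc3ccc(Oc4cccc(C(F)(F)F)c4)cc3s2)cc1` gives 51000 nM in this assay. Compound 2 `N=C(N)NCCCOc1ccc(CNc2nc3ccc(Oc4ccc(F)cc4)cc3s2)cc1` gives 244000 nM, the higher of the two numbers; its nearest neighbour is compound 1, whose number is lower by a margin beyond the scatter, though the two compounds differ in more than one place, so only the two values themselves can be compared.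

Compound 3 `CN(C)CCCOc1ccc(CNc2nc3ccc(Oc4ccc(F)cc4)cc3s2)cc1` has not yet been measured. It is built from compound 2 by one change: a group of 3 heavy atoms (2 carbon, 1 nitrogen; no ring) in place of a group of 4 heavy atoms (1 carbon, 3 nitrogen; no ring), on a saturated chain carbon, three bonds along the chain from an oxygen on an aromatic ring. Among the measured compounds shown here, compound 1 carries the same dimethylamino group, yet it differs from compound 3 in a second place as well, so no single step in this assay isolates the group exchange. For the measured compounds named here, with only two measured compounds the direction of the change is therefore uncertain, and a step of moderate size toward a lower number, with a range that also admits no change beyond the scatter, is expected for the step of a 2.7-fold lower number from compound 2 to compound 3 (0.43 log units; beyond the scatter). On that basis compound 3 is estimated at 90000 nM in this assay, within a range from 30000 nM to 250000 nM.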

Compound 3, half-maximal inhibitory concentration: 40000 nM
The estimate for compound 3 lay 2.3-fold (0.35 log units) above the measured number; low and high end bracket the measured number.
By their numbers in this assay, from the lowest: compounds 3 and 1 (each within the scatter of the next); then compound 2.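

In this assay, among the compounds shown here, dimethylamino in place of the guanidine chain end, on a saturated chain carbon, three bonds along the chain from an oxygen on an aromatic ring, gives a 6.1-fold lower number from compound 2 to compound 3 (0.79 log units; beyond the scatter) and so reads this exchange on its own for the first time, with the rest of the molecule held constant. The other step, 4-fluorophenyl in place of 3-(trifluoromethyl)phenyl on an oxygen on an aromatic ring, gives a 1.3-fold lower number from compound 1 to compound 3 (0.11 log units; within the scatter) and so does not separate these two aryl groups when dimethylamino ends the chain. No evidence beyond the assay numbers bears on this result.

From the compounds shown here alone, it remains open whether the same exchange would give a step of similar size in a compound carrying 3-(trifluoromethyl)phenyl, since a single pair defines the step. Also open, going by these compounds, is how other chain ends, such as a primary amine, a pyrrolidine or a morpholine, or a longer chain carrying dimethylamino, would read in this assay at this position.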